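Replacing Methyl with Phenylcarbamoyl: Expected Cytotoxicity Shift

The compounds below may be only part of what the source reports. "The series", "measured", "known", "first", "only" and "open" are said of these compounds alone.

Compound 3 `CNc1c(C)c(C(OC(C)(C)C)C(=O)O)c(-c2ccc(C)c(C)c2)c(C)c1-c1ccc(C)c(C)c1` stands at the low end of the three measured values in an ADME assay on MT4 cells (Homo sapiens) for cytotoxicity, read by MTT assay, with a stated time of 4 days (on this read-out higher numbers stand for lower toxicity in this test and lower numbers for higher toxicity in this test), where compound 3 gives 8800 nM. Compound 2 `Cc1ccc(-c2c(C)c(-c3ccc(C)c(C)c3)c(C(OC(C)(C)C)C(=O)O)c(C)c2NC(=O)c2ccccc2)cc1C` gives 9100 nM, a value within the scatter of compound 3, while compound 1 `CNC(=O)Nc1c(C)c(C(OC(C)(C)C)C(=O)O)c(-c2ccc(C)c(C)c2)c(C)c1-c1ccc(C)c(C)c1` gives 20000 nM. Compound 4 `Cc1ccc(-c2c(C)c(-c3ccc(C)c(C)c3)c(C(OC(C)(C)C)C(=O)O)c(C)c2NC(=O)Nc2ccccc2)cc1C` differs from compound 3 by phenylcarbamoyl in place of methyl on a nitrogen on an aromatic ring. Among the compounds with values here, two measured steps bear on this change: a 2.3-fold lower number from compound 1 to compound 3 (0.36 log units; beyond the scatter), where a methylcarbamoyl group was lost from the same nitrogen, and a 1.0-fold lower number from compound 2 to compound 3 (0.01 log units; within the scatter), where a benzoyl group was lost. The entering group combines the carbamoyl feature of compound 1 with the phenyl of compound 2, so a modest rise is expected, a 1.6-fold higher number from compound 3 to compound 4 (0.20 log units; within the scatter). Compound 4 is therefore estimated at 14000 nM, within a range from 6000 nM to 35000 nM.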

Compound 4, half-maximal cytotoxic concentration: 8000 nM
Beside the measured number, compound 4's estimate is 1.8-fold (0.24 log units) above it, and the stated range covers the measured number.
By their numbers in this assay, from the lowest: compounds 4, 3 and 2 (each within the scatter of the next); then compound 1.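

In this assay, phenylcarbamoyl on the nitrogen brings no change beyond the scatter from the methyl of compound 3 (a 1.1-fold lower number from compound 3 to compound 4 (0.04 log units; within the scatter)) or from the benzoyl of compound 2 (a 1.1-fold lower number from compound 2 to compound 4 (0.06 log units; within the scatter)). The carbamoyl link alone therefore does not go with the higher number of compound 1, since phenyl in place of methyl on the amide-type nitrogen gives a 2.5-fold lower number from compound 1 to compound 4 (0.40 log units; beyond the scatter). No measurement shown explains this gap. From the compounds shown here alone, it remains open whether ethyl or cyclohexyl on that amide-type nitrogen would read like compound 1 or like compound 4.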